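Thiophene in place of phenyl on an imine carbon

This account rests on a few compounds, and the source may have more. Where it says the series, first, only, none or still open, it means among the compounds named here.

Two measured compounds, compound 1 `CN1CCN(c2ccc(Nc3ncc(/N=C/c4ccccc4)c(NC4CCCC4)n3)cc2)CC1` and compound 2 `CN1CCN(c2ccc(Nc3ncc(/N=C/c4cccs4)c(NC4CCCC4)n3)cc2)CC1`, differ in a single place: thiophen-2-yl in place of phenyl on a carbon with a double bond to nitrogen. In a functional assay on MCF7 cells (Homo sapiens) for antiproliferative activity, read by MTT assay (on this read-out lower numbers stand for stronger inhibition and higher numbers for weaker inhibition), compound 2 gives 33900 nM. For compound 1 this assay reports only a limit rather than a number, > 100000 nM. The change thus produced an at least 2.9-fold lower number from compound 1 to compound 2 (0.46 log units; beyond the scatter).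

Compound 3 `CC(C)Nc1nc(Nc2ccc(S(N)(=O)=O)cc2)ncc1/N=C/c1ccccc1` is built on a different core; the difference between the two cores is not broken down here. For compound 3 this assay again reports only a limit, > 100000 nM.

Compound 4 `CC(C)Nc1nc(Nc2ccc(S(N)(=O)=O)cc2)ncc1/N=C/c1cccs1` has not been measured yet and differs from compound 3 by the same change: thiophen-2-yl in place of phenyl on a carbon with a double bond to nitrogen. On these data alone, a step of similar size is expected, an at least 2.0-fold lower number from compound 3 to compound 4 (0.30 log units; that floor lies within the scatter), resting on an at least 2.9-fold lower number from compound 1 to compound 2 (0.46 log units; beyond the scatter), though the starting point for compound 3 is itself only a limit, so the true size of that step is unknown. The expected value for compound 4 in this assay is therefore 50000 nM, estimated to lie between 15000 nM and 150000 nM, and because the limit of > 100000 nM in this assay, at which 2 of the 3 values shown sit, there remains a fair chance that this assay again reports only a limit for compound 4.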

Compound 4, half-maximal inhibitory concentration: 50200 nM
Compound 4: the middle estimate sits 1.0-fold (0.00 log units) below what was measured; the measured number falls inside the stated range.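

In this assay, replacing phenyl with thiophen-2-yl on a carbon with a double bond to nitrogen gives an at least 1.9-fold lower number from compound 3 to compound 4 (0.29 log units; that floor lies within the scatter). On both cores, the thiophen-2-yl compound returns a real number where the phenyl compound returns only a limit, so the change points the same way in these two pairs, but the size of the two steps cannot be compared: the same change on two cores in this assay, an at least 2.9-fold lower number (0.46 log units; beyond the scatter) from compound 1 to compound 2 and an at least 1.9-fold lower number (0.29 log units; that floor lies within the scatter) from compound 3 to compound 4; the limit leaves it open whether they differ. Two pairs are a small basis for a rule, and neither step has a known true size, since each starts from the same ceiling of the read-out: the limit of > 100000 nM in this assay, at which 2 of the 4 values shown sit.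

The compounds shown leave open whether adding an amine or a carboxylic acid to the thiophen-2-yl group would shift the number any further. They also leave open whether the same change would give a step in the same direction on a third core, or whether a longer chain on the carbon with a double bond to nitrogen would do as well.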